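Trimming a diol tail: compound 3 to compound 4

This account rests on a few compounds, and the source may have more. Where it says the series, first, only, none or still open, it means among the compounds named here.

The three measured compounds share one core and differ only in the tail on the saturated ring. Compound 1 `Cn1ncc(Cl)c1-c1cc(C(=O)N[C@@H]2CN[C@H](CCn3cncn3)C[C@H]2c2ccc(Cl)c(Cl)c2)oc1Cl` gives 560 nM in a functional assay on HCT-116 cells (Homo sapiens) for antiproliferative activity, read by sulforhodamine B assay, with a stated time of 72 h (on this read-out higher numbers stand for weaker inhibition and lower numbers for stronger inhibition), compound 2 `Cn1ncc(Cl)c1-c1cc(C(=O)N[C@@H]2CN[C@H](CC(=O)NC3CC3)C[C@H]2c2ccc(Cl)c(Cl)c2)oc1Cl` gives 740 nM, and compound 3 `Cn1ncc(Cl)c1-c1cc(C(=O)N[C@@H]2CN[C@H](CC(=O)NCC(O)CO)C[C@H]2c2ccc(Cl)c(Cl)c2)oc1Cl` gives 7090 nM, the highest of the three numbers, so the weakest inhibitor here.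

Compound 4 `Cn1ncc(Cl)c1-c1cc(C(=O)N[C@@H]2CN[C@H](CC(=O)NCCO)C[C@H]2c2ccc(Cl)c(Cl)c2)oc1Cl` keeps the amide tail but differs from compound 3 by hydrogen in place of hydroxymethyl on a saturated chain carbon bound to an oxygen on a saturated carbon and a saturated chain carbon.

The steps of a 13-fold higher number from compound 1 to compound 3 (1.10 log units; beyond the scatter) and a 9.6-fold higher number from compound 2 to compound 3 (0.98 log units; beyond the scatter) show that the diol amide tail costs potency. Removing part of that diol is expected to recover some of it, so a moderately lower number is expected, a 2.4-fold lower number from compound 3 to compound 4 (0.37 log units; beyond the scatter). Compound 4 is therefore estimated at 3000 nM, within 1200 nM to 8000 nM.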

Compound 4, half-maximal inhibitory concentration: 670 nM
Beside the measured number, compound 4's estimate is 4.5-fold (0.65 log units) above it, outside the stated range (below it).
By their numbers in this assay, from the lowest: compounds 1, 4 and 2 (each within the scatter of the next); then compound 3.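

Replacing the hydroxymethyl with hydrogen, which turns 2,3-dihydroxypropyl into 2-hydroxyethyl, gives an 11-fold lower number from compound 3 to compound 4 (1.02 log units; beyond the scatter) in this assay, so the weak result of compound 3 goes with this one small piece and not with the amide tail as a whole. The amide tail with a single hydroxyl matches the other tails, with a 1.1-fold lower number from compound 2 to compound 4 (0.04 log units; within the scatter) and a 1.2-fold higher number from compound 1 to compound 4 (0.08 log units; within the scatter). Nothing measured here gives a reason for this.

Still open, going by these compounds, is whether 2-aminoethyl or the longer 3-hydroxypropyl on the amide-type nitrogen would match compound 4 or fall back towards compound 3.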